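A few compounds are considered here, and "the series" means these few. Any claim that something is new, unique, unknown or untested is made for them only; others in the source may bear on it.

Series so far:
compound 1 `C=C1CCCC(C)(C)[C@@H]1C[C@H](O)/C(C)=C/CC[C@@H]1[C@@]2(C)CCCC(C)(C)[C@@H]2CC[C@@]1(C)O`: 4 ug/mL
compound 2 `C=C1CCCC(C)(C)[C@@H]1C[C@@H](O)/C(C)=C/CC[C@@H]1[C@@]2(C)CCCC(C)(C)[C@@H]2CC[C@@]1(C)O`: > 10 ug/mL
compound 3 `C=C1CCCC(C)(C)[C@@H]1C[C@H](OC(=O)c1ccccc1)/C(C)=C/CC[C@@H]1[C@@]2(C)CCCC(C)(C)[C@@H]2CC[C@@]1(C)O`: > 10 ug/mL

The read-out is an ADME assay on MCF7 cells (Homo sapiens) for cytotoxicity, read by MTT assay; a lower number here means that less compound is needed, a higher number that more compound is needed for the effect. In this assay, for the measured compounds named here, compound 1 gives the only true number, 4 ug/mL. Compound 2 sits at > 10 ug/mL, which is a limit and not a number. Compound 3 stands at > 10 ug/mL, also a limit and not a number, and this is the limit of > 10 ug/mL in this assay, at which 2 of the 3 values shown sit.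

Compound 4 `C=C1CCCC(C)(C)[C@@H]1C[C@@H](OC(=O)c1ccccc1)/C(C)=C/CC[C@@H]1[C@@]2(C)CCCC(C)(C)[C@@H]2CC[C@@]1(C)O` is the next case: the two compounds have the same atoms and bonds and differ only in configuration as drawn: 1 of 7 stereo elements differ; a stereocentre at a saturated chain carbon is drawn S in compound 3 and R in compound 4. The stereocentre at a saturated chain carbon is drawn S in compound 3 and R in compound 4.

Going by the values given here, two measured steps bear on this. The nearest is an at least 2.5-fold higher number from compound 1 to compound 2 (0.39 log units; beyond the scatter), the same kind of inversion without the benzoyl, and it stands out given (the fact that compounds 1 and 2 differ only in the configuration as drawn). The other is an at least 2.5-fold higher number from compound 1 to compound 3 (0.39 log units; beyond the scatter), from benzoyl in place of hydrogen. Both are known only as lower bounds, and both raise the number, so no fall is expected on inversion of the benzoate. The expected change is a step that the limit leaves unreadable from compound 3 to compound 4, most likely unresolved at the limit. For compound 4 the estimate is 13 ug/mL, with an expected range from 5 ug/mL to 30 ug/mL.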

Compound 4, concentration for half-maximal effect: > 10 ug/mL
Compound 4 ended at the assay's limit; the forecaster's own chance of this, stated with the estimate: 70%; the middle value is on the limit's open side.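

In this assay compound 4 gives > 10 ug/mL, a limit and not a number, so neither its step from compound 3 nor its step from compound 2 can be read. The compounds shown leave open whether the configuration at the saturated chain carbon changes the number when benzoyl is present.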